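Benzylamino in Place of Arylthio on a Shared Core

A few compounds are considered here, and "the series" means these few. Any claim that something is new, unique, unknown or untested is made for them only; others in the source may bear on it.

Three compounds share one fused core and differ in the group attached on an aromatic carbon next to the ring nitrogen. Compound 1 `CCOC(=O)[C@H](CCC(=O)O)NC(=O)c1ccc(Sc2nc3cc(N)cc(N)c3nc2-c2ccccc2)cc1` carries an arylthio group bearing an ester-amide side chain, and in a functional assay on KM12 cells (Homo sapiens) for inhibition, read by sulforhodamine B assay, with a stated time of 48 h (on this read-out lower numbers stand for stronger inhibition of growth and higher numbers for weaker inhibition of growth), compound 1 gives 24000 nM. Compound 2 `Nc1cc(N)c2nc(-c3ccccc3)c(Sc3ccc(F)cc3)nc2c1` carries a (4-fluorophenyl)sulfanyl group, and in this assay compound 2 gives 20900 nM, the second highest of the three numbers; the gap to compound 1 lies within the scatter, while compound 3 `COc1cc(CNc2nc3cc(N)cc(N)c3nc2-c2ccccc2)cc(OC)c1OC`, which carries a benzylamino group with three methoxy groups, gives 479 nM in this assay, a lower number well beyond the scatter.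

Compound 4 `Nc1cc(N)c2nc(-c3ccccc3)c(NCc3ccc(F)cc3)nc2c1` differs from compound 2 in one place: (4-fluorobenzyl)amino in place of (4-fluorophenyl)sulfanyl on an aromatic carbon. Within the data shown here, no step between measured compounds isolates this exchange, so the expectation rests on compound 3, whose value 479 nM shows that a benzylamino group at this position can go with a far lower number than either arylthio compound. The step from compound 2 to compound 4 is therefore expected to be a sizeable fall, an 8.4-fold lower number from compound 2 to compound 4 (0.92 log units; beyond the scatter), beyond the scatter. For compound 4 in this assay the estimated value is 2500 nM, expected to lie between 600 nM and 10000 nM.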

Compound 4, concentration for 50% growth inhibition: 2820 nM
Compound 4: the middle estimate sits 1.1-fold (0.05 log units) below what was measured, within the range that was stated.
By their numbers in this assay, from the lowest: compound 3; then compound 4; then compounds 2 and 1 (each within the scatter of the next).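

The exchange of (4-fluorophenyl)sulfanyl for (4-fluorobenzyl)amino on the shared core gives, in this assay, a 7.4-fold lower number from compound 2 to compound 4 (0.87 log units; beyond the scatter). Among these compounds, this is the first single-place step at this aromatic carbon, and it shows that the lower number can follow from the change of link alone, since the fluorinated aromatic ring is present on both sides. The entering group also carries a hydrogen-bond donor that the leaving group lacks, but no measurement here says what lies behind the step.

The exchange alters the link atom and its length together, so the compounds shown leave open what a benzylsulfanyl group or a directly attached anilino group would give at this carbon. They also leave open how a plain amino group or a longer phenethylamino chain would compare with the (4-fluorobenzyl)amino group.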